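Swapping dimethylamino for acetyl on a pyrazole series

This account rests on a few compounds, and the source may have more. Where it says the series, first, only, none or still open, it means among the compounds named here.

Two compounds of a shared core have been run through a functional assay on T47D cells (Homo sapiens) for cytotoxicity, read by sulforhodamine B assay, with a stated time of 48 h, tested at 0.001 uM; a lower number here means a stronger effect, a higher number a weaker effect of the compound at the concentration tested. Compound 1, `COc1cc(C)cc(-c2c(-c3ccnc(-c4ccc(N(C)C)cc4)c3)cnn2CC#N)c1`, gives 90% in this assay. Compound 2, `COc1cc(C)cc(-c2nn(CC#N)cc2-c2ccc(-c3cccc(C(C)=O)c3)nc2)c1`, gives 88% in this assay, and the gap between compound 1 and compound 2 lies within the usual scatter of this kind of measurement, so the two are read as alike.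

Compound 3, `COc1cc(C)cc(-c2c(-c3ccnc(-c4ccc(C(C)=O)cc4)c3)cnn2CC#N)c1`, has not yet been measured. It is built from compound 1 by one change: acetyl in place of dimethylamino on an aromatic carbon. For the measured compounds named here, nothing measured so far isolates exactly this change, so no step size can be taken from the data. Compound 2, which also carries an acetyl group on an outer ring, sits near compound 1, which suggests that compound 3 will stay in the same region. The step from compound 1 to compound 3 in this assay is therefore expected to be small, a number 2 percentage points lower from compound 1 to compound 3 (within the scatter), not beyond the scatter. Compound 3 is estimated to give 88%, likely between 72% and 100%.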

Compound 3, a percentage reported as activity, at one concentration (the size of the read-out at that concentration, not a potency): 93%
Compound 3: middle estimate off by 5 percentage points, on the low side; measured number inside the range.
By their numbers in this assay, from the lowest: compounds 2, 1 and 3 (each within the scatter of the next).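

In this assay, for the compounds shown here, the direct swap of dimethylamino for acetyl, on an aromatic carbon para to a large group, gives a number 3 percentage points higher from compound 1 to compound 3 (within the scatter) and so provides the first reading of this exact change. The earlier pair differed in more than one place and could only hint at this, whereas here the 4-(dimethylamino)phenyl and 4-acetylphenyl versions of the shared core read as alike at the one concentration tested, which shows that this position tolerates either group in this read-out. No measurement at hand explains why these two groups read alike.

Going by these compounds, whether this holds for other kinds of group at the same place remains open, for example a carboxylic acid, a primary amine or a longer alkyl chain. A single swap also cannot show whether any group at this position can move the read-out beyond the scatter.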